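Ring-opened amino acid tail replaces the carboxypiperidine

The source may hold more compounds than are shown below. What is called first, only, known or untested is meant among the compounds shown, and "the series" means these compounds.

Compound 1 `COc1ccc(/C=C\c2cc(OC)c(OC)c(OC)c2)cc1OCc1ccc(CN2CC[C@H](C(=O)O)C2)cc1`: > 10000 nM
Compound 2 `COc1ccc(/C=C\c2cc(OC)c(OC)c(OC)c2)cc1OCc1ccc(CN2CCCCC2C(=O)O)cc1`: 5400 nM
Compound 3 `COc1ccc(/C=C\c2cc(OC)c(OC)c(OC)c2)cc1OCc1ccc(CN2CC[C@H](O)C2)cc1`: 7200 nM

Three compounds sharing one core carry different polar groups on a saturated chain carbon bound to an aromatic carbon. In a functional assay on MC-38 cells (Mus musculus) for antiproliferative activity, read by CCK-8 assay, with a stated time of 48 h (on this read-out higher numbers stand for weaker inhibition and lower numbers for stronger inhibition), compound 1 gives only a limit, (the limit of > 10000 nM in this assay, at which 1 of the 3 values shown sits). Compound 2 gives the lowest of the two numbers in this assay; its nearest neighbour is compound 3, and the gap a 1.3-fold higher number from compound 2 to compound 3 (0.12 log units; within the scatter) lies within the scatter. The step of an at least 1.8-fold lower number from compound 1 to compound 2 (0.26 log units; that floor lies within the scatter) has a floor that also lies within the scatter.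

Compound 4 `COc1ccc(/C=C\c2cc(OC)c(OC)c(OC)c2)cc1OCc1ccc(CN[C@H](C(=O)O)[C@@H](C)O)cc1` is not yet measured. It differs from compound 2 by (1-carboxy-2-hydroxypropyl)amino in place of 2-carboxypiperidin-1-yl on a saturated chain carbon bound to an aromatic carbon. Among the compounds with values here, two measured steps bear on this: an at least 1.8-fold lower number from compound 1 to compound 2 (0.26 log units; that floor lies within the scatter), where the ring and the position of the carboxy change, and a 1.3-fold higher number from compound 2 to compound 3 (0.12 log units; within the scatter), where hydroxy replaces carboxy. Neither step is resolved beyond the scatter, so the expectation for compound 4 is no step beyond the scatter in this assay, with a risk that the result is reported as a limit. The estimated step is a 1.2-fold higher number from compound 2 to compound 4 (0.08 log units; within the scatter). For compound 4 the expected value in this assay is 6500 nM, within the range 2500 nM to 15000 nM.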

Compound 4, half-maximal inhibitory concentration: > 10000 nM
Compound 4: only a limit was reported (the forecaster's own chance of this, stated with the estimate: 30%); middle value at least 1.5-fold (0.18 log units) away from the limit.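

In this assay, compound 4, which carries the ring-free (1-carboxy-2-hydroxypropyl)amino group on the saturated chain carbon bound to an aromatic carbon, gives only a limit, > 10000 nM. Against the two measured numbers, the readings are an at least 1.8-fold higher number from compound 2 to compound 4 (0.26 log units; that floor lies within the scatter) and an at least 1.3-fold higher number from compound 3 to compound 4 (0.14 log units; that floor lies within the scatter), so this change to an open chain shows no gain in inhibition, yet neither floor establishes a loss beyond the scatter. The step between compound 1 and compound 4 cannot be read, and this result adds a second compound to the limit of the assay: the limit of > 10000 nM in this assay, at which 2 of the 4 values shown sit.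

Going by these compounds, how far compound 4 actually lies past its limit stays open, and so does the part played by each feature of the new group, since its ring opening, hydroxy group and two defined stereocentres enter together. A simple open-chain amine without the carboxylic acid, a plain glycine-type chain without the hydroxy group, or the other stereoisomers of the (1-carboxy-2-hydroxypropyl)amino group could separate these features in this assay.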